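A few compounds are considered here, and "the series" means these few. Any claim that something is new, unique, unknown or untested is made for them only; others in the source may bear on it.

In a functional assay on HeLa cells (Homo sapiens) for antiproliferative activity, with a stated time of 48 h (on this read-out higher numbers stand for weaker inhibition and lower numbers for stronger inhibition), compound 1 (`C=C(Br)C(=O)Nc1ccc(/C=C/C(=O)c2ccc(Br)cc2)cc1`) gives 1000 nM and compound 2 (`C=C(Br)C(=O)Nc1ccc(C(=O)/C=C/c2ccccc2)cc1`) gives 960 nM as its result. These two numbers lie within the usual scatter of each other, so compound 2 cannot be told apart from compound 1. Compound 3 (`C=C(Br)C(=O)Nc1ccc(C(=O)/C=C/c2cccc(OC)c2)cc1`) differs from compound 2 in one place (methoxy in place of hydrogen on an aromatic carbon): methoxy in place of hydrogen on an aromatic carbon. For the measured compounds named here, no measured pair shows what this change does, so no step beyond the scatter is expected in this assay, in either direction. The estimated step (a 1.4-fold lower number from compound 2 to compound 3 (0.14 log units; within the scatter)) is therefore small. Compound 3 is expected to give about 700 nM with an estimated range from 250 nM to 1800 nM in this measurement.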

Compound 3, half-maximal inhibitory concentration: 500 nM
Compound 3: the middle estimate sits 1.4-fold (0.15 log units) above what was measured; the range from low to high includes it.
By their numbers in this assay, from the lowest: compounds 3, 2 and 1 (each within the scatter of the next).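

For the compounds shown here, the first reading of this change, phenyl to 3-methoxyphenyl, in this assay is a 1.9-fold lower number from compound 2 to compound 3 (0.28 log units; within the scatter) and so cannot be told apart from no change. At this place on the ring, a methoxy group is therefore tolerated, with compound 3 keeping activity in the same range as compound 2. Nothing measured here bears on why the two compounds read alike.

As far as these compounds go, what other groups would do at this place, such as an amine, a carboxylic acid or a longer ethoxy chain, remains open. A single pair also cannot say whether methoxy would behave the same way on another core, such as that of compound 1.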